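Swapping methoxy for chloro on a sulfonyl-bearing core

A few compounds are considered here, and "the series" means these few. Any claim that something is new, unique, unknown or untested is made for them only; others in the source may bear on it.

Measured so far in an ADME assay on microsomes from liver (Homo sapiens) for metabolic stability, tested at 2.5 uM; on this read-out lower numbers stand for slow clearance and higher numbers for fast clearance:
- compound 1, `COc1cccc(-c2c(S(=O)(=O)c3ccc(OC)c(Cl)c3)cnc3cc(F)ccc23)c1`, gives 1.71 mL/min
- compound 2, `COc1ccc(S(=O)(=O)c2cnc3cc(F)ccc3c2-c2cccc(Cl)c2)cc1Cl`, gives 1.19 mL/min
- compound 3, `COc1cccc(-c2c(S(=O)(=O)c3cc(Cl)cc(Cl)c3)cnc3cc(F)ccc23)c1`, gives 1.51 mL/min

Compound 4, `O=S(=O)(c1cc(Cl)cc(Cl)c1)c1cnc2cc(F)ccc2c1-c1cccc(Cl)c1`, has not been measured yet. It differs from compound 3 by chloro in place of methoxy on an aromatic carbon. The same change has already been made once, from compound 1 to compound 2: chloro in place of methoxy on an aromatic carbon. There it gave a 1.4-fold lower number from compound 1 to compound 2 (0.16 log units; within the scatter). The two cores on which the change is made are not identical: compound 3 differs from compound 1 by 3,5-dichlorophenyl in place of 3-chloro-4-methoxyphenyl on a sulfonyl sulfur, and that difference gave a 1.1-fold lower number from compound 1 to compound 3 (0.05 log units; within the scatter). The place of the change, on an aromatic carbon of a six-membered aromatic ring of carbon only, meta to a large group, is the same in both pairs.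

Because the earlier step of a 1.4-fold lower number from compound 1 to compound 2 (0.16 log units; within the scatter) stayed within the scatter, the step from compound 3 to compound 4 is expected to be of similar size, estimated as a 1.4-fold lower number from compound 3 to compound 4 (0.14 log units; within the scatter). Compound 4 is therefore estimated at 1.1 mL/min, with a likely range from 0.6 mL/min to 2 mL/min.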

Compound 4, intrinsic clearance in a liver preparation (reported as CLH), per the amount of preparation that the assay uses: 0.93 mL/min
Compound 4: the middle estimate sits 1.2-fold (0.07 log units) above what was measured; the measured number falls inside the stated range.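

In this assay chloro in place of methoxy gave a 1.6-fold lower number from compound 3 to compound 4 (0.21 log units; within the scatter) and reads the same on both cores: the same change on two cores in this assay, a 1.4-fold lower number (0.16 log units; within the scatter) from compound 1 to compound 2 and a 1.6-fold lower number (0.21 log units; within the scatter) from compound 3 to compound 4, 1.1-fold (0.05 log units) apart, within the scatter of two such steps. The other change in this set, 3,5-dichlorophenyl in place of 3-chloro-4-methoxyphenyl on the sulfonyl sulfur, gave a 1.3-fold lower number from compound 2 to compound 4 (0.11 log units; within the scatter) and also carries over from one core to the other: the same change on two cores in this assay, a 1.1-fold lower number (0.05 log units; within the scatter) from compound 1 to compound 3 and a 1.3-fold lower number (0.11 log units; within the scatter) from compound 2 to compound 4, 1.1-fold (0.05 log units) apart, within the scatter of two such steps. Each change therefore looks transferable across these four compounds, but every step lies within the usual scatter of repeated measurements, so the data do not show that either change truly alters clearance or that the agreement would hold on any other core.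

The compounds shown leave open what an amine, a nitrile or a longer chain such as ethoxy would do on the aromatic carbon that carries methoxy or chloro here. Also open, on these data alone, is whether a carboxylic acid on the phenyl group attached to the sulfonyl sulfur would give a step beyond the scatter.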